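This account rests on a few compounds, and the source may have more. Where it says the series, first, only, none or still open, it means among the compounds named here.

In a functional assay on MCF7 cells (Homo sapiens) for cytotoxicity, read by MTT assay, with a stated time of 48 h (on this read-out higher numbers stand for weaker inhibition and lower numbers for stronger inhibition), compound 2 `CC(C)n1c(/C=C2/C(=O)Nc3ccc(F)cc32)nc2ccccc21` gives 29000 nM. In this assay, compound 1 `CC(C)n1c(/C=C2/C(=O)Nc3ccc(Br)cc32)nc2ccccc21` gives 14900 nM. These two values lie within the scatter of each other. For compound 3 `CCn1c(/C=C2/C(=O)Nc3ccc(Br)cc32)nc2ccccc21` the entry reads "not determined" (no result reported). The change to compound 4 `Cn1c(/C=C2/C(=O)Nc3ccc(F)cc32)nc2ccccc21` is methyl in place of isopropyl on an aromatic nitrogen. Going by the values given here, the only measured step, a 1.9-fold higher number from compound 1 to compound 2 (0.29 log units; within the scatter), is fluoro in place of bromo on an aromatic carbon. It stays within the scatter but does not touch that nitrogen, so it offers only weak guidance, and no data point to a direction. No shift beyond the scatter is expected in this assay. The expected step is a 1.0-fold higher number from compound 2 to compound 4 (0.01 log units; within the scatter). For compound 4 the estimate is 30000 nM, with an expected range of 10000 nM to 80000 nM.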

Compound 4, half-maximal inhibitory concentration: 31600 nM
For compound 4 the middle estimate is 1.1-fold (0.02 log units) below the measured one; low and high end bracket the measured number.
By their numbers in this assay, from the lowest: compounds 1, 2 and 4 (each within the scatter of the next, the first and the last beyond it).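

On the aromatic nitrogen, methyl in place of isopropyl gives a 1.1-fold higher number from compound 2 to compound 4 (0.04 log units; within the scatter) in this assay. Going by these compounds alone, this is the first reading at that nitrogen, and with the fluoro group held fixed, the two groups are not told apart in this assay. No supporting measurement bears on this result.

On these data alone, whether a benzyl group or a longer chain ending in an amine on that nitrogen would move the number beyond the scatter stays open. So does the effect of a carboxylic acid on the shared core.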